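This account rests on a few compounds, and the source may have more. Where it says the series, first, only, none or still open, it means among the compounds named here.

Within the data shown here, compound 1, `CC(=O)c1ccc(NC(=O)/C=C/C(=O)N2C/C(=C\c3ccc([N+](=O)[O-])cc3)C(=O)/C(=C/c3ccc([N+](=O)[O-])cc3)C2)cc1`, gives 390 nM in a functional assay on Molt4/C8 cells (Homo sapiens) for cytotoxicity (a lower number here means a stronger inhibitor, a higher number a weaker inhibitor), the lower of the two numbers known so far, though the gap to compound 2 lies within the scatter. Compound 2, `O=C(/C=C/C(=O)N1C/C(=C\c2ccccc2)C(=O)/C(=C/c2ccccc2)C1)Nc1ccccc1`, gives 520 nM in this assay. Compound 3, `O=C(/C=C/C(=O)N1C/C(=C\c2ccc([N+](=O)[O-])cc2)C(=O)/C(=C/c2ccc([N+](=O)[O-])cc2)C1)Nc1ccccc1`, differs from compound 1 by hydrogen in place of acetyl on an aromatic carbon. Among the measured compounds shown here, no measured pair shows this change by itself, so the step of a 1.2-fold higher number from compound 1 to compound 3 (0.06 log units; within the scatter) is expected to be small, with no direction beyond the scatter. Compound 3 is expected to give 450 nM in this assay, between 200 nM and 1000 nM.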

Compound 3, half-maximal inhibitory concentration: 360 nM
For compound 3 the middle estimate is 1.3-fold (0.10 log units) above the measured one, and the stated range covers the measured number.
By their numbers in this assay, from the lowest: compounds 3, 1 and 2 (each within the scatter of the next).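

Going from 4-acetylphenyl to phenyl gives the first direct reading at this position: in this assay the step of a 1.1-fold lower number from compound 1 to compound 3 (0.03 log units; within the scatter) shows that the two compounds cannot be told apart. On the core of compound 1, then, an acetyl group and a hydrogen on this aromatic carbon give numbers within the scatter of each other. Nothing measured here offers an explanation for this result.

Only acetyl and hydrogen are shown at this position, so what an amine, a carboxylic acid or a longer chain would give remains open. As far as these compounds go, whether the same swap would give a similarly small step on the core of compound 2 is also open.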